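A few compounds are considered here, and "the series" means these few. Any claim that something is new, unique, unknown or untested is made for them only; others in the source may bear on it.

Compound 1 `COc1ccc(C2N=C(SCc3cccc(Cl)c3)NC(C)=C2C(=O)Nc2ccc(Br)cc2)cc1` and compound 2 `COc1ccc(C2N=C(SCc3ccc(Cl)cc3)NC(C)=C2C(=O)Nc2ccc(Br)cc2)cc1` share one core and differ only by 4-chlorophenyl in place of 3-chlorophenyl on a saturated chain carbon bound to a sulfur. In a functional assay on the whole organism (artery, strain albino) with Rattus norvegicus as the target, with a stated time of 15 min, at a dose of 10 mg/kg by the oral route (on this read-out lower numbers stand for less inhibition and higher numbers for more inhibition at the one dose given (going by the name of the read-out)), compound 1 gives 3.1%, and compound 2 gives 3.1%; the step is no change at the digits printed from compound 1 to compound 2 (within the scatter). Compound 3 `CC1=C(C(=O)Nc2ccc([N+](=O)[O-])cc2)C(c2ccc(Br)cc2)N=C(SCc2cccc(Cl)c2)N1` carries another core; the difference between the two cores is not broken down here. In this assay compound 3 gives 2.1%, a number within the scatter of compound 1 and of compound 2. Compound 4 `CC1=C(C(=O)Nc2ccc([N+](=O)[O-])cc2)C(c2ccc(Br)cc2)N=C(SCc2ccc(Cl)cc2)N1` is not yet measured. Among the compounds with values here, compound 4 differs from compound 3 by 4-chlorophenyl in place of 3-chlorophenyl on a saturated chain carbon bound to a sulfur, the same change as the one between compound 1 and compound 2. The step is expected to be small, a number 0.9 percentage points higher from compound 3 to compound 4 (within the scatter), because no change at the digits printed from compound 1 to compound 2 (within the scatter) showed no movement for the same change and all three measured numbers lie close together. Compound 4 is therefore expected to give 3%, between 0% and 10%.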

Compound 4, a percentage reported as inhibition, in the whole organism at one dose (the size of the read-out at that dose, not a potency): 3.1%
Estimate against measurement, compound 4: 0.1 percentage points below; the measured number falls inside the stated range.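

In this assay, 4-chlorophenyl in place of 3-chlorophenyl on a saturated chain carbon bound to a sulfur gives a number 1 percentage points higher from compound 3 to compound 4 (within the scatter). Within the data shown here, the change reads the same on both cores: the same change on two cores in this assay, no change at the digits printed (within the scatter) from compound 1 to compound 2 and a number 1 percentage points higher (within the scatter) from compound 3 to compound 4, 1 percentage points apart, within the scatter of two such steps This shows only that the change moves the read-out by no more than the scatter on these two cores at this one dose; it does not show how the change would carry over to a core with a larger read-out, or what either core contributes.

The compounds shown leave open whether an amine or a carboxylic acid in place of the chlorine, or a longer chain between the sulfur and the ring, would move the read-out. From the compounds shown here alone, whether the two chlorophenyl groups stay level at another dose also remains open.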